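A few compounds are considered here, and "the series" means these few. Any claim that something is new, unique, unknown or untested is made for them only; others in the source may bear on it.

Compound 1 `COc1ccc(C(O)c2c(C)oc3c([C@H]4CCN(C)C[C@H]4O)c(O)cc(O)c3c2=O)cc1Br`: 0%
Compound 2 `CN1CC[C@H](c2c(O)cc(O)c3c(=O)cc(/C=C/c4ccc(Cl)cc4)oc23)[C@H](O)C1`: 70%

In a functional assay on Caco-2 cells (Homo sapiens) for inhibition, read by MTT assay, with a stated time of 48 h, tested at 10 uM (a higher number here means more inhibition of growth at the concentration tested, a lower number less inhibition of growth), compound 2 stands highest of the two compounds measured, at 70%. In the same assay, compound 1 gives 0%. The gap between these two compounds lies beyond the scatter. Compound 3 `CN1CC[C@H](c2c(O)cc(O)c3c(=O)cc(/C=C/c4ccccc4Cl)oc23)[C@H](O)C1` differs from compound 2 in one place: 2-chlorophenyl in place of 4-chlorophenyl on a double-bonded chain carbon bound to a double-bonded chain carbon. Going by the values given here, no measured pair shows what such a change does in this assay, so the expectation starts from compound 2 at 70% and leans only modestly downward, with wide uncertainty. The expected change is a number 15 percentage points lower from compound 2 to compound 3 (beyond the scatter). For compound 3 the estimated value is 55%, with an expected range from 25% to 80%.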

Compound 3, percent growth inhibition at one concentration: 65%
Beside the measured number, compound 3's estimate is 10 percentage points below it; the range from low to high includes it.
By their numbers in this assay, from the lowest: compound 1; then compounds 3 and 2 (each within the scatter of the next).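

In this assay the exchange of 4-chlorophenyl for 2-chlorophenyl on a double-bonded chain carbon bound to a double-bonded chain carbon gives a number 5 percentage points lower from compound 2 to compound 3 (within the scatter) and is the first single-place comparison among these compounds. At this position, the two chlorophenyl groups cannot be told apart in growth inhibition. No evidence is available to explain this result.

The compounds shown leave open whether the chlorine is needed at all. They also do not show how an amine or a carboxylic acid on the phenyl ring would fare.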